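The source may hold more compounds than are shown below. What is called first, only, known or untested is meant among the compounds shown, and "the series" means these compounds.

Of the compounds shown here, three have so far been measured in an ADME assay on microsomes from liver (Homo sapiens) for metabolic stability, tested at 2.5 uM; on this read-out lower numbers stand for slow clearance and higher numbers for fast clearance. Compound 1 `O=S(=O)(c1ccc(F)cc1)c1cnc2cc(F)ccc2c1-c1cccc(F)c1` gives 0.95 mL/min, compound 2 `COc1cccc(S(=O)(=O)c2cnc3cc(F)ccc3c2-c2cccc(F)c2)c1` gives 3.36 mL/min, and compound 3 `COc1ccc(-c2c(S(=O)(=O)c3ccc(OC)cc3)cnc3cc(F)ccc23)cc1` gives 1.18 mL/min. Compound 3 thus stands second highest of the three: compound 1 lies within the scatter of it, while compound 2 lies beyond it. Among the measured compounds shown here, the one measured step, a 3.5-fold higher number from compound 1 to compound 2 (0.55 log units; beyond the scatter), concerns the group on the sulfonyl sulfur. Compound 4 `COc1ccc(S(=O)(=O)c2cnc3cc(F)ccc3c2-c2cccc(F)c2)cc1` differs from compound 3 at another place: 3-fluorophenyl in place of 4-methoxyphenyl on an aromatic carbon. For the measured compounds named here, no measured step touches that place, so nothing points to a direction, and compound 4 keeps the 4-methoxyphenyl on the sulfonyl sulfur that compound 3 carries. The expected step is a 1.1-fold higher number from compound 3 to compound 4 (0.04 log units; within the scatter), none beyond the scatter. Compound 4 is estimated at 1.3 mL/min, between 0.6 mL/min and 2.8 mL/min.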

Compound 4, intrinsic clearance in a liver preparation (reported as CLH), per the amount of preparation that the assay uses: 2.94 mL/min
Compound 4: middle estimate off by 2.3-fold (0.35 log units), on the low side, and the stated range ends below it.
By their numbers in this assay, from the lowest: compounds 1 and 3 (each within the scatter of the next); then compounds 4 and 2 (each within the scatter of the next).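

In this assay, among the compounds shown here, the group on the aromatic carbon of the core now proves to matter: with 4-methoxyphenyl kept on the sulfonyl sulfur, 3-fluorophenyl in place of 4-methoxyphenyl gives a 2.5-fold higher number from compound 3 to compound 4 (0.40 log units; beyond the scatter) as the first reading at this position. On the sulfur, a 1.1-fold lower number from compound 2 to compound 4 (0.06 log units; within the scatter) does not separate the two methoxyphenyl groups, while a 3.1-fold higher number from compound 1 to compound 4 (0.49 log units; beyond the scatter) shows that methoxy in place of fluoro gives faster clearance here too. Nothing available accounts for these steps. Still open, as far as these compounds go, is how an amine or a carboxylic acid would behave at either position.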